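A Halogen Swap in a Series That Shows No Inhibition

The compounds below may be only part of what the source reports. "The series", "measured", "known", "first", "only" and "open" are said of these compounds alone.

Measured compounds:
- Compound 1 `Fc1ccccc1NC(=S)N/N=C/c1ccc2ccccc2n1` gives only the limit > 100000 nM in a functional assay on HL-60 cells (Homo sapiens) for antiproliferative activity, read by sulforhodamine B assay, with a stated time of 72 h; on this read-out higher numbers stand for weaker inhibition and lower numbers for stronger inhibition.
- Compound 2 `NC(=S)N/N=C/c1cc2ccccc2s1` gives only the limit > 100000 nM in this assay.
- Compound 3 `NC(=S)N/N=C/c1cnc2ccccc2n1` gives only the limit > 100000 nM in this assay.

None of the three measured compounds reaches a measurable half-maximal inhibitory concentration in this assay. Compound 1 sits at the limit of > 100000 nM in this assay, at which 3 of the 3 values shown sit, so its value is a boundary of the assay and not a number, and its standing relative to compound 2 and compound 3 cannot be ranked: all three are equally unresolved.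

Compound 4 `S=C(N/N=C/c1ccc2ccccc2n1)Nc1cccc(Cl)c1` is the one not yet measured. It differs from compound 1 by 3-chlorophenyl in place of 2-fluorophenyl on an amide-type nitrogen. Among the compounds with values here, no step between two measured compounds exists here to show how a change at that nitrogen moves the read-out, so there is no measured precedent for the size or direction of this step. With the whole series resting at a limit, the expectation is no change beyond the usual scatter, and most likely another limit.

Compound 4 is therefore expected to give 100000 nM, with a range from 30000 nM to 300000 nM. The step of a number no higher from compound 1 to compound 4 (the limit leaves the size open) is expected to be negligible.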

Compound 4, half-maximal inhibitory concentration: 28800 nM
Compound 4: the middle estimate sits 3.5-fold (0.54 log units) above what was measured; the measured number lies below the stated range.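

Putting 3-chlorophenyl in place of 2-fluorophenyl on the amide-type nitrogen gives an at least 3.4-fold lower number from compound 1 to compound 4 (0.54 log units; beyond the scatter) in this assay, so a change at this place can bring a compound of this series off the limit and onto a measured number. Compound 1 gives > 100000 nM, which is a limit and not a number. The step can therefore be read only as a minimum, and its true size stays open, because one of its two ends rests on a limit shared by most of the series: the limit of > 100000 nM in this assay, at which 3 of the 4 values shown sit.

This swap changes both the halogen and the group's name-given place on the phenyl ring, so the compounds shown cannot say which of the two matters; a 2-chlorophenyl or a 3-fluorophenyl group on the same nitrogen would separate them. Also open, as far as these compounds go, is whether the read-out would move further with a group that carries no halogen at all, such as a 3-methoxyphenyl or a plain phenyl group, or with a chain such as butyl.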